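Swapping One Aromatic Group on Compound 3

The source may report more compounds than this note shows. Statements on the series, on what has been measured and on what is new or still open speak of the compounds shown alone.

In a functional assay on MV4-11 cells (Homo sapiens) for antiproliferative activity, read by luminescence and CellTiter-Glo, with a stated time of 72 h (a higher number here means a weaker inhibitor, a lower number a stronger inhibitor), compound 1 `Cc1noc(C)c1-c1ccc(-n2ncc3ccc(-c4c(C)noc4C)cc32)c(Cl)c1` gives 2800 nM as its result. Compound 2 `COc1ccc(Cn2nc(Nc3cccc(C(C)C)c3)c3ccc(-c4c(C)noc4C)cc32)cc1` gives 8100 nM in this assay as well, and compound 3 `CNc1cc(-c2ccc3cnn(Cc4ccc(OC)cc4)c3c2)cn(C)c1=O` gives 2700 nM there. The numbers for compound 3 and compound 1 cannot be told apart, since their gap lies within the usual scatter of repeated measurements. Compound 2 has a clearly higher number than compound 3, which makes it the weaker inhibitor of that pair.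

Compound 4 `CNc1cc(-c2ccc3cnn(Cc4ccc(F)c([N+](=O)[O-])c4)c3c2)cn(C)c1=O` has not been measured yet. It differs from compound 3 in one place, with 4-fluoro-3-nitrophenyl in place of 4-methoxyphenyl on a saturated chain carbon bound to an aromatic nitrogen. The counted change is 4-fluoro-3-nitrophenyl in place of 4-methoxyphenyl on a saturated chain carbon bound to an aromatic nitrogen and the rest of the structure stays the same.

Going by the values given here, no two measured compounds differ in just one place, so the data offer no direct guide to the effect of this swap in this assay so far. A slight drift toward a lower number is expected, but no step beyond the scatter. The expected change is a 1.4-fold lower number from compound 3 to compound 4 (0.13 log units; within the scatter) and it remains a rough estimate. Compound 4 is estimated at 2000 nM with an expected range from 600 nM to 6500 nM in this measurement.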

Compound 4, half-maximal inhibitory concentration: 130 nM
The estimate for compound 4 lay 15-fold (1.19 log units) above the measured number; the measured number lies below the stated range.
By their numbers in this assay, from the lowest: compound 4; then compounds 3 and 1 (each within the scatter of the next); then compound 2.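

The group on the saturated chain carbon bound to an aromatic nitrogen proves to matter a great deal: in this assay, putting 4-fluoro-3-nitrophenyl in place of 4-methoxyphenyl gives a 21-fold lower number from compound 3 to compound 4 (1.32 log units; beyond the scatter), with the rest of the structure unchanged. Going by these compounds alone, the earlier compounds could not show this, since no two of them differed in just one place, so this is the first direct sign that the read-out responds to a change at this position. No measurement of any property of these compounds is at hand to account for the size of the step.

The swap removes the methoxy group and brings in both a fluorine and a nitro group, so the compounds shown cannot say how much of the step belongs to each of these changes. A plain phenyl ring, a ring carrying only the fluorine or only the nitro group, or an amine or a carboxylic acid in place of the nitro group would help to separate them.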